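A Pyrazole Amide Swapped for a Fused Ring

The source may hold more compounds than are shown below. What is called first, only, known or untested is meant among the compounds shown, and "the series" means these compounds.

Compound 1 (`CCCC(Oc1ccc(-n2cc(C(=O)N(C)C)cn2)cc1)c1ccc(C(=O)NCCC(=O)O)cc1`) gives (< 13 mL/min/kg), a limit
Compound 2 (`O=C(O)CCNC(=O)c1ccc(C(Oc2ccc(-n3cc(C(F)(F)F)cn3)cc2)C2CCC2)cc1`) gives (26 mL/min/kg)

In an ADME assay on microsomes from liver (Homo sapiens) for metabolic stability (on this read-out lower numbers stand for slow clearance and higher numbers for fast clearance), compound 1 gives (< 13 mL/min/kg), which is a limit of the assay and not a number. From the compounds shown here alone, it therefore stands at the low end of the values shown (the limit of < 13 mL/min/kg in this assay, at which 1 of the 2 values shown sits), and its exact clearance is unknown. Within the data shown here, compound 2, which also lacks the 4-(dimethylcarbamoyl)-1H-pyrazol-1-yl group, gives (26 mL/min/kg), the only number available for a compound without that group.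

Compound 3 (`CCCC(Oc1ccc(-n2cc3c(n2)CCCC3)cc1)c1ccc(C(=O)NCCC(=O)O)cc1`) keeps the core of compound 1 and changes one group (a group of 9 heavy atoms (7 carbon, 2 nitrogen; one five-membered aromatic ring with 2 hetero atoms, one six-membered non-aromatic ring of carbon only) in place of a group of 10 heavy atoms (6 carbon, 3 nitrogen, 1 oxygen; one five-membered aromatic ring with 2 hetero atoms), on an aromatic carbon). The 4-(dimethylcarbamoyl)-1H-pyrazol-1-yl group leaves, and a group with one five-membered aromatic ring with 2 hetero atoms and one six-membered non-aromatic ring of carbon only enters in its place. Among the measured compounds shown here, no measured pair isolates this change, so the forecast in this assay is uncertain. The expected change is upward and moderate (an at least 1.8-fold higher number from compound 1 to compound 3 (0.26 log units; that floor lies within the scatter)), near the edge of the usual scatter. For compound 3 the estimated clearance is (24 mL/min/kg), with an expected range from (13 mL/min/kg) to (50 mL/min/kg).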

Compound 3, clearance: 48 mL/min/kg
Estimate against measurement, compound 3: 2.0-fold (0.30 log units) below; the range from low to high includes it.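

In this assay, among these compounds, the earlier compounds offered no pair that differed in one place, and compound 3 now supplies one for the group on an aromatic carbon of the six-membered aromatic ring, para to a large group. With the rest of the core of compound 1 unchanged, putting the fused group with its six-membered non-aromatic ring in place of 4-(dimethylcarbamoyl)-1H-pyrazol-1-yl gives an at least 3.6-fold higher number from compound 1 to compound 3 (0.56 log units; beyond the scatter), so this position clearly matters for clearance in human liver microsomes, and the exchange moves the read-out in the unfavourable direction. The size of that step is only a floor, as the reading for compound 1 is a limit of the assay and not a number: the limit of < 13 mL/min/kg in this assay, at which 1 of the 3 values shown sits.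

Because the exchange removes the dimethylcarbamoyl group and adds the six-membered ring together, the compounds shown leave open which of the two accounts for the rise. A nitrile or a primary carboxamide in place of the dimethylcarbamoyl group on the same pyrazole would help to separate the two, a comparison that the compounds shown do not offer.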